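The compounds below may be only part of what the source reports. "The series", "measured", "known", "first", "only" and "open" are said of these compounds alone.

In an assay on HEK293 cells for inhibition of Voltage-dependent T-type calcium channel subunit alpha-1G (Homo sapiens), read by patch clamp (on this read-out higher numbers stand for weaker inhibition and lower numbers for stronger inhibition), compound 2 `O=C(CCCN1CCN(c2ccccc2)CC1)Nc1ccc(Cl)cc1` gives 4470 nM, the highest of the two numbers at hand. For the measured compounds named here, compound 1 `O=C(CCCCN1CCN(c2cccc(Cl)c2)CC1)Nc1ccccc1Cl` gives 1910 nM in this assay, a lower number, though these two compounds differ in several places at once, so no single step links them. Compound 3 `O=C(CCCN1CCN(c2ccccc2F)CC1)Nc1ccc(Cl)cc1` is yet to be measured; it differs from compound 2 by fluoro in place of hydrogen on an aromatic carbon. Going by the values given here, with no measured pair showing this change, the step is expected to be modest, toward a slightly lower number or none beyond the scatter, as a 1.4-fold lower number from compound 2 to compound 3 (0.15 log units; within the scatter). Compound 3 is estimated at 3200 nM, within 1200 nM to 8500 nM.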

Compound 3, half-maximal inhibitory concentration: 3630 nM
The estimate for compound 3 lay 1.1-fold (0.05 log units) below the measured number, and the stated range covers the measured number.
By their numbers in this assay, from the lowest: compounds 1, 3 and 2 (each within the scatter of the next, the first and the last beyond it).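

In this assay, the change from phenyl to 2-fluorophenyl gives a 1.2-fold lower number from compound 2 to compound 3 (0.09 log units; within the scatter) and so does not separate the two compounds. For the compounds shown here, this is the first comparison here that differs in only one place, showing that a single fluoro on this aromatic carbon, ortho to a large group, leaves the read-out within the usual scatter. No measurement at hand offers an explanation for this result. Still open, going by these compounds, is whether a chloro or methoxy group at this same carbon would also leave the number within the scatter. Also open, on these data alone, is how fluoro would fare on another carbon of that ring.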